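A few compounds are considered here, and "the series" means these few. Any claim that something is new, unique, unknown or untested is made for them only; others in the source may bear on it.

Measured compounds in a functional assay on CWR22R cells (Homo sapiens) for antiproliferative activity, read by CCK-8 assay, with a stated time of 6 days; on this read-out higher numbers stand for weaker inhibition and lower numbers for stronger inhibition:
- compound 1 `CCN(c1ccc(C#N)c(Cl)c1)c1cc(-c2ccncc2)ccc1C`: 1030 nM
- compound 3 `N#Cc1ccc(N2CCc3cc(-c4ccncc4)ccc3C2)cc1C(F)(F)F`: 6940 nM
- compound 2 `Cc1noc(C)c1-c1cccc(Oc2ccc(C#N)c(C(F)(F)F)c2)c1`: "not determined" (no result reported)

Compound 1 holds the lowest of the two numbers shown. Within the data shown here, its nearest neighbour, compound 3, sits at a higher number, and the gap between compound 1 and compound 3 lies beyond the usual scatter of repeated measurements; no single-point step between them is described, so only the two values themselves can be compared. Compound 2 contributes no number to the comparison.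

The step under consideration leads from compound 1 to compound 4 `CCN(c1ccc(C#N)c(Cl)c1)c1cc(-c2ccoc2)ccc1C`. The change, computed from the two structures, is furan-3-yl in place of pyridin-4-yl on an aromatic carbon.

Among the measured compounds shown here, no step between measured compounds covers this kind of change, so there is no measured precedent for its size. The expectation is a modest weakening, roughly a step of a 2.4-fold higher number from compound 1 to compound 4 (0.39 log units; beyond the scatter) in this assay, though a result within the scatter of compound 1 would not be surprising. Compound 4 is therefore estimated at 2500 nM, with a range from 800 nM to 8000 nM.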

Compound 4, half-maximal inhibitory concentration: > 30000 nM
Compound 4: a limit, no number (the forecaster's own chance of this, stated with the estimate: 10%); middle value at least 12-fold (1.07 log units) away from the limit.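

Compound 4 gives a limit in this assay, not a number: the limit of > 30000 nM in this assay, at which 1 of the 4 values shown sits. Furan-3-yl in place of pyridin-4-yl on this aromatic carbon, meta to a large group and para to a methyl group, gives an at least 29-fold higher number from compound 1 to compound 4 (1.46 log units; beyond the scatter), the first step read at this position, and it shows that activity here is not indifferent to which aromatic ring is attached. The two groups are printed with the same counts of hydrogen-bond donors and acceptors, so those counts alone do not separate them.

This single pair does not tell which difference between the two rings carries the step, and the limit leaves its full size unknown. Going by these compounds, how phenyl, pyridin-3-yl or an aminopyridine ring would stand at this position remains open.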